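The source may hold more compounds than are shown below. What is called first, only, known or untested is meant among the compounds shown, and "the series" means these compounds.

Compound 1 is `Cc1ccc2nc(Nc3nc4ccccc4s3)sc2c1`. In a functional assay on U-937 cells (Homo sapiens) for cytotoxicity, read by MTT assay, with a stated time of 48 h (on this read-out lower numbers stand for stronger inhibition and higher numbers for weaker inhibition), compound 1 gives 48400 nM. Compound 2 is `Cc1ccc2nc(Nc3nc4ccc(F)cc4s3)sc2c1`. Compound 2 reaches only the limit of this assay, > 50000 nM. Compound 3 is `Cc1ccc2nc(NC(=S)Nc3ccccc3)sc2c1`. Compound 3 likewise gives only a limit, > 50000 nM.

Compound 1 and compound 2 differ by fluoro in place of hydrogen on an aromatic carbon. The step this made is an at least 1.0-fold higher number from compound 1 to compound 2 (0.01 log units; that floor lies within the scatter), and its size cannot be fixed beyond a floor because of the limit of > 50000 nM in this assay, at which 2 of the 3 values shown sit. How the core of compound 3 differs from the core of compound 1 is not broken down here. Compound 4, `Cc1ccc2nc(NC(=S)Nc3ccc(F)cc3)sc2c1`, carries the same kind of change relative to compound 3: fluoro in place of hydrogen on an aromatic carbon. The place is not the same: in the earlier pair the fluoro sits on a ring that is part of a fused or bridged system of two rings, meta to a fused ring and para to a fused ring, whereas here it sits on a six-membered aromatic ring of carbon only, para to a large group. The expected step here is a step that the limit leaves unreadable from compound 3 to compound 4. This expectation rests on compound 3 giving only a limit, > 50000 nM, and on the earlier change, an at least 1.0-fold higher number from compound 1 to compound 2 (0.01 log units; that floor lies within the scatter). Compound 4 is therefore expected to sit around 70000 nM, most likely between 30000 nM and 200000 nM, and quite possibly to show only a limit again.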

Compound 4, half-maximal inhibitory concentration: > 50000 nM
Compound 4 gave a limit, no number; the forecaster's own chance of this, stated with the estimate: 80%; the middle value lies beyond the limit too.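

Compound 3 and compound 4 each stop at a limit and give no number, so no step can be read between them, because of this: the limit of > 50000 nM in this assay, at which 3 of the 4 values shown sit. From the compounds shown here alone, whether phenyl to 4-fluorophenyl changes anything in this assay stays open.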